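A few compounds are considered here, and "the series" means these few. Any claim that something is new, unique, unknown or untested is made for them only; others in the source may bear on it.

Measured compounds:
Compound 1, `CN1[C@@H]2c3[nH]c4ccccc4c3C[C@H]1[C@H](C#N)N1[C@@H](CNC(=O)c3ccc(Cl)cc3)c3[nH]c4ccccc4c3C[C@@H]21`, gives 130 nM in a functional assay on HT-29 cells (Homo sapiens) for cytotoxicity, read by MTT assay, with a stated time of 72 h; on this read-out lower numbers stand for stronger inhibition and higher numbers for weaker inhibition.
Compound 2, `CN1[C@@H]2c3[nH]c4ccccc4c3C[C@H]1[C@H](C#N)N1[C@@H](CNC(=O)c3cc4ccccc4s3)c3[nH]c4ccccc4c3C[C@@H]21`, gives 640 nM in this assay.
Compound 3, `CN1[C@@H]2c3[nH]c4ccccc4c3C[C@H]1[C@H](C#N)N1[C@@H](CNC(=O)/C=C/c3cccc(C(F)(F)F)c3)c3[nH]c4ccccc4c3C[C@@H]21`, gives 5060 nM in this assay.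

All three share one core and differ only in the group attached to the carbonyl carbon of the amide. Compound 3 stands at the top of the numbers, that is, at the weak end: the change from the group in compound 2 gives a 7.9-fold higher number from compound 2 to compound 3 (0.90 log units; beyond the scatter), and from the group in compound 1 it gives a 39-fold higher number from compound 1 to compound 3 (1.59 log units; beyond the scatter). Both steps lie beyond the scatter, so compound 3 is the weakest of the three.

Compound 4, `CN1[C@@H]2c3[nH]c4ccccc4c3C[C@H]1[C@H](C#N)N1[C@@H](CNC(=O)/C=C/c3ccccc3)c3[nH]c4ccccc4c3C[C@@H]21`, keeps the ethenyl linker of compound 3 and differs only in hydrogen in place of trifluoromethyl on an aromatic carbon. Among the measured compounds shown here, none of the measured steps bears on this change: each of them swaps the whole group on the carbonyl carbon, and no pair differs only in a trifluoromethyl. The measured steps therefore give no guide to direction, and the expectation is no change beyond the scatter, a 1.0-fold lower number from compound 3 to compound 4 (0.01 log units; within the scatter). Compound 4 is expected to give about 5000 nM in this assay, within a range from 1500 nM to 16000 nM.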

Compound 4, half-maximal inhibitory concentration: 1400 nM
Estimate against measurement, compound 4: 3.6-fold (0.55 log units) above, outside the stated range (below it).
By their numbers in this assay, from the lowest: compound 1; then compound 2; then compound 4; then compound 3.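

In this assay, among the compounds shown here, hydrogen in place of trifluoromethyl gives a 3.6-fold lower number from compound 3 to compound 4 (0.56 log units; beyond the scatter), a step beyond the scatter and the first reading that isolates this one aromatic carbon, since the earlier steps all swapped the whole group on the carbonyl carbon. The change closes only part of the gap. The 2-phenylethenyl group still trails the other two groups: the steps read a 2.2-fold higher number from compound 2 to compound 4 (0.34 log units; beyond the scatter) and an 11-fold higher number from compound 1 to compound 4 (1.03 log units; beyond the scatter), so the missing trifluoromethyl does not bring this series level with the 1-benzothiophen-2-yl or 4-chlorophenyl amides. Nothing among the data offers an explanation for the difference between trifluoromethyl and hydrogen at this position.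

As far as these compounds go, with only hydrogen and trifluoromethyl compared on this ring carbon, it stays open whether a fluorine, a methyl, an amine or a carboxylic acid there would land nearer compound 3 or compound 4. From the compounds shown here alone, it also stays open what the ethenyl linker itself contributes, for instance how a saturated ethyl chain between the carbonyl and the phenyl ring would compare with it.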